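From ethyl to tert-butyl on a barely active compound

The compounds below may be only part of what the source reports. "The series", "measured", "known", "first", "only" and "open" are said of these compounds alone.

Going by the values given here, in a functional assay on HCT-116 cells (Homo sapiens) for inhibition, read by CCK-8 assay, with a stated time of 72 h, tested at 8 uM (on this read-out lower numbers stand for less inhibition of growth and higher numbers for more inhibition of growth at the one concentration tested), compound 1 (`CCc1ccc(SCc2ccc(/C=C/C(=O)Nc3ccccc3N)cc2)cc1`) gives 2.68% and so holds the lower of the two numbers so far. Compound 2 (`COc1ccc(SCc2ccc(C(=O)Nc3ccccc3N)cc2)cc1OC`) gives 91.5% and the gap between them lies far beyond the usual scatter. Compound 3 (`CC(C)(C)c1ccc(SCc2ccc(/C=C/C(=O)Nc3ccccc3N)cc2)cc1`) has not yet been measured. It is compound 1 with one change: tert-butyl in place of ethyl on an aromatic carbon. Among the compounds with values here, no two measured compounds differ in just one place, so nothing yet shows how large such a swap can be in this assay on its own. The best guide is compound 1 at 2.68% as the closest relative. The expected step (a number 5.3 percentage points higher from compound 1 to compound 3 (within the scatter)) is small, upward if anything, and probably within the scatter. For compound 3 the estimated value is 8% with an expected range from 0% to 30% as its ends.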

Compound 3, percent growth inhibition at one concentration: 39%
Beside the measured number, compound 3's estimate is 31 percentage points below it; the measured number lies above the stated range.
By their numbers in this assay, from the lowest: compound 1; then compound 3; then compound 2.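

In this assay, replacing ethyl with tert-butyl on the aromatic carbon gives a number 36.3 percentage points higher from compound 1 to compound 3 (beyond the scatter). Going by these compounds alone, this is the first comparison here between two compounds that differ in one place, and it shows that this single change can move growth inhibition well beyond the usual scatter. The position para to a large group is therefore not indifferent to what sits on it, although the data offer no measured explanation for why tert-butyl gives the higher number.

With only ethyl and tert-butyl compared at this position, the compounds shown cannot tell whether the rise is specific to tert-butyl or would also appear with another group, such as isopropyl, methoxy or an amine. Also open, from the compounds shown here alone, is whether the same swap would have a similar effect on the core of compound 2.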